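The compounds below may be only part of what the source reports. "The series", "measured", "known", "first", "only" and "open" are said of these compounds alone.

Compound 1 `O=C(O)CCCOc1ccc(-c2cccc(Oc3ccccc3)c2)cc1` gives 6800 nM in a functional assay on isolated protein for agonist activity at Free fatty acid receptor 1 (Homo sapiens), read by HTRF and inositol phosphate accumulation, with a stated time of 60 min; on this read-out higher numbers stand for an effect only at larger amounts of compound and lower numbers for an effect already at smaller amounts. Compound 2 `Cc1ccc(Oc2cccc(-c3ccc(OCCCC(=O)O)cc3)c2)cc1` reaches only a limit of this assay, > 9950 nM. Compound 3 `Cc1cc(-c2cc(OC(F)(F)F)ccc2F)ccc1OCCCC(=O)O` gives 9260 nM in this assay.

The change methyl in place of hydrogen on an aromatic carbon from compound 1 gives an at least 1.4-fold higher number from compound 1 to compound 2 (0.16 log units; that floor lies within the scatter), resting on (the limit of > 9950 nM in this assay, at which 1 of the 3 values shown sits). Compound 4 `Cc1cc(-c2cc(OC(F)(F)F)ccc2F)cc(C)c1OCCCC(=O)O` carries the same kind of change from compound 3, (methyl in place of hydrogen on an aromatic carbon), but the place differs: in compound 2 the methyl sits para to a large group, in compound 4 ortho to a 3-carboxypropoxy group, meta to a large group and meta to a methyl group. The difference between the cores of compound 1 and compound 3 is not broken down here.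

For compound 4 a step of a 1.4-fold higher number from compound 3 to compound 4 (0.15 log units; within the scatter) is expected, close to the earlier one, since compound 3 already gives 9260 nM. Compound 4 is therefore estimated at 13000 nM, between 5000 nM and 35000 nM, and a limit is likely.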

Compound 4, half-maximal effective concentration: > 9950 nM
Compound 4 was reported as a limit; the forecaster's own chance of this, stated with the estimate: 60%; the middle value does not contradict the limit.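

Methyl in place of hydrogen on an aromatic carbon gives an at least 1.0-fold higher number from compound 3 to compound 4 (0.03 log units; that floor lies within the scatter), and this step rests on a limit, not on a number. Set beside the earlier case, the change looks alike on the two cores, but only as far as the floors go: the same change on two cores in this assay, an at least 1.4-fold higher number (0.16 log units; that floor lies within the scatter) from compound 1 to compound 2 and an at least 1.0-fold higher number (0.03 log units; that floor lies within the scatter) from compound 3 to compound 4; the limit leaves it open whether they differ. Going by these compounds, on neither core does the methyl bring a lower number in this assay, yet the true size of either step stays unknown, so it cannot be said whether the change carries over unaltered from one core to the other: the limit of > 9950 nM in this assay, at which 2 of the 4 values shown sit.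

The compounds shown leave open whether a chlorine or a methoxy group in the place of this methyl would read differently. They also leave open what an amide or a longer chain would give in place of the 3-carboxypropoxy group.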